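Arylamino in place of piperidin-1-yl on the shared core

The source may report more compounds than this note shows. Statements on the series, on what has been measured and on what is new or still open speak of the compounds shown alone.

Compound 1 `O=C1C(N2CCCCC2)=CC(=O)c2c1nc1n2[C@H]2OC[C@@H](O)[C@H]2OC1` carries piperidin-1-yl on a double-bonded ring carbon of the shared core. In a functional assay on HeLa cells (Homo sapiens) for inhibition, read by sulforhodamine B assay (on this read-out lower numbers stand for stronger inhibition and higher numbers for weaker inhibition), compound 1 gives only a limit, > 16000 nM. Compound 2 `O=C1C=C(N2CCCCC2)C(=O)c2c1nc1n2[C@H]2OC[C@@H](O)[C@H]2OC1` likewise gives only a limit in this assay, > 16000 nM. Compound 3 `O=C1C=C(Nc2cccc(Cl)c2)C(=O)c2c1nc1n2[C@H]2OC[C@@H](O)[C@H]2OC1` gives 6040 nM in this assay. Among the compounds with values here, the one measured step, an at least 2.6-fold lower number from compound 2 to compound 3 (0.42 log units; beyond the scatter), is the only guide; because of the limit of > 16000 nM in this assay, at which 2 of the 3 values shown sit, its size is known only as a lower bound.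

Compound 4 `O=C1C(Nc2cccc(F)c2)=CC(=O)c2c1nc1n2[C@H]2OC[C@@H](O)[C@H]2OC1` differs from compound 1 in this way: (3-fluorophenyl)amino in place of piperidin-1-yl on a double-bonded ring carbon. The step from compound 2 to compound 3 swaps the same piperidin-1-yl for an arylamino group, and the halogen on the aryl ring differs only in kind. A step of comparable direction and roughly comparable size is therefore expected here. The estimated value for compound 4 is 8000 nM, with a range from 3000 nM to 20000 nM; this means an expected at least 2.0-fold lower number from compound 1 to compound 4 (0.30 log units; that floor lies within the scatter). With compound 1 at a limit, the true step could also be larger than estimated.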

Compound 4, half-maximal inhibitory concentration: > 8000 nM
Compound 4 was reported as a limit (the forecaster's own chance of this, stated with the estimate: 35%); the middle value sits exactly at the limit.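

Compound 4 gives only a limit in this assay, > 8000 nM. Within the data shown here, compound 1 also gives only a limit, > 16000 nM, so no step between compound 1 and compound 4 can be read. Still open, going by these compounds, is whether (3-fluorophenyl)amino in place of piperidin-1-yl changes inhibition on this core at all.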